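Swapping 3-cyanophenyl for 2-chlorophenyl: what size of step?

The source may hold more compounds than are shown below. What is called first, only, known or untested is meant among the compounds shown, and "the series" means these compounds.

Values from a functional assay on B16-F10 cells (Mus musculus) for inhibition, read by MTT assay, with a stated time of 72 h; on this read-out higher numbers stand for weaker inhibition and lower numbers for stronger inhibition:
Compound 1 `CC1(C)CC(NC(=S)Nc2cccc(C#N)c2)c2cc(Br)ccc2O1` gives 7000 nM
Compound 2 `CC1(C)CC(NC(=S)Nc2cccc(C#N)c2)c2cc(F)ccc2O1` gives 35000 nM
Compound 3 `CC1(C)CC(NC(=S)Nc2cccc(C#N)c2)c2cc(Cl)ccc2O1` gives 6000 nM

Compound 1 stands with the lower numbers of this short set. Its nearest neighbour shows a 1.2-fold lower number from compound 1 to compound 3 (0.07 log units; within the scatter) and its furthest shows a 5.0-fold higher number from compound 1 to compound 2 (0.70 log units; beyond the scatter) on the same read-out.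

Compound 4 `CC1(C)CC(NC(=S)Nc2ccccc2Cl)c2cc(Br)ccc2O1` has not yet been measured. It keeps the core of compound 1 but carries 2-chlorophenyl in place of 3-cyanophenyl on an amide-type nitrogen.

Among the compounds with values here, no measured step touches that group. All three exchange one halogen on the core, so they offer only a sense of size: the widest (a 5.8-fold lower number from compound 2 to compound 3 (0.77 log units; beyond the scatter)) is still modest. Their direction says nothing about the new change. A small step is therefore expected in this assay with no firm direction, and a modest one either way would not surprise. The estimate amounts to a 1.1-fold higher number from compound 1 to compound 4 (0.06 log units; within the scatter) as an expected step, with wide uncertainty. For compound 4 the expected value is an estimated 8000 nM with a range from 2500 nM to 30000 nM as the expected span.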

Compound 4, half-maximal inhibitory concentration: 17000 nM
Estimate against measurement, compound 4: 2.1-fold (0.33 log units) below; measured number inside the range.
By their numbers in this assay, from the lowest: compounds 3 and 1 (each within the scatter of the next); then compound 4; then compound 2.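

In this assay the exchange of 3-cyanophenyl for 2-chlorophenyl gives a 2.4-fold higher number from compound 1 to compound 4 (0.39 log units; beyond the scatter) and so shows that the group on the amide-type nitrogen can move the number. The earlier steps shown here changed only the halogen on the core, whereas this one shows that a change at a second place in the molecule also has a modest effect, here towards weaker inhibition. Nothing available explains why the number moves in this direction.

The compounds shown do not separate the effect of removing the nitrile from that of adding the chlorine, and they show 2-chlorophenyl only with the bromo core of compound 1. On these data alone, how a plain phenyl, a methoxyphenyl or a cyclohexyl group on this nitrogen would read also remains open.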